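Benzyl in place of 4-methylphenyl at the amine nitrogen

The compounds below may be only part of what the source reports. "The series", "measured", "known", "first", "only" and "open" are said of these compounds alone.

Of the compounds shown here, three have been measured in a functional assay on HepG2 cells (Homo sapiens) for antiproliferative activity, read by CCK-8 assay, with a stated time of 72 h, tested at 2 uM; a higher number here means a stronger effect of the compound at the concentration tested, a lower number a weaker effect. Compound 1 `Cc1ccc(Nc2nc(Cl)nc3c2ncn3Cc2ccc(C(=O)Nc3ccccc3N)cc2)cc1` gives 76.2%, compound 3 `CC1CCN(c2nc(Cl)nc3c2ncn3Cc2ccc(C(=O)Nc3ccccc3N)cc2)CC1` gives 1.22%, and compound 2 `Cc1ccc(Nc2nc(Cl)nc3c2ncn3Cc2ccc(/C=C/C(=O)Nc3ccccc3N)cc2)cc1` gives 33.6%, the second highest of the three. Replacing (4-methylphenyl)amino by 4-methylpiperidin-1-yl on an aromatic carbon brought a number 75 percentage points lower from compound 1 to compound 3 (beyond the scatter), and lengthening the amide side produced a number 42.6 percentage points lower from compound 1 to compound 2 (beyond the scatter). Compound 4 `Nc1ccccc1NC(=O)/C=C/c1ccc(Cn2cnc3c(NCc4ccccc4)nc(Cl)nc32)cc1` differs from compound 2 by benzyl in place of 4-methylphenyl on a nitrogen on an aromatic ring. Going by the values given here, the only measured step at that nitrogen, from compound 1 to compound 3, was large and downward, so a downward step is expected here too, though smaller, as the nitrogen keeps its carbon substituent. Compound 4 is therefore expected to give 15%, between 0% and 35%, in this assay. The expected step is a number 18.6 percentage points lower from compound 2 to compound 4 (beyond the scatter).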

Compound 4, a percentage reported as inhibition, at one concentration (the size of the read-out at that concentration, not a potency): 11.5%
Beside the measured number, compound 4's estimate is 3.5 percentage points above it, within the range that was stated.
By their numbers in this assay, from the lowest: compound 3; then compound 4; then compound 2; then compound 1.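

In this assay, benzyl in place of 4-methylphenyl gives a number 22.1 percentage points lower from compound 2 to compound 4 (beyond the scatter), although both groups hold the same seven carbons and one aromatic ring. The earlier step at this nitrogen replaced the whole (4-methylphenyl)amino group, whereas this one shows that the read-out also responds to joining the same atoms differently. Nothing available explains this step.

On these data alone, it remains open whether benzylamino would lower the read-out similarly alongside the (2-aminophenyl)carbamoyl group of compound 1. As far as these compounds go, how phenylamino or a longer 2-phenylethylamino chain would read at this nitrogen is also open.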